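Para-substituent on the benzylsulfanyl group: fluoro to hydrogen

The source may report more compounds than this note shows. Statements on the series, on what has been measured and on what is new or still open speak of the compounds shown alone.

Measured compounds:
compound 1 `Cc1cc(Nc2ccc(C(=O)/C=C/c3ccc4ccccc4c3)cc2)n2nc(SCc3ccc([N+](=O)[O-])cc3)nc2n1`, 1130 nM
compound 2 `COc1ccc(CSc2nc3nc(C)cc(Nc4ccc(C(=O)/C=C/c5ccc6ccccc6c5)cc4)n3n2)cc1`, 250 nM
compound 3 `Cc1cc(Nc2ccc(C(=O)/C=C/c3ccc4ccccc4c3)cc2)n2nc(SCc3ccc(F)cc3)nc2n1`, 320 nM

In a functional assay on SW-620 cells (Homo sapiens) for cytotoxicity, read by MTT assay, with stated times of 4 h and 72 h, tested at 5 uM (on this read-out lower numbers stand for stronger inhibition and higher numbers for weaker inhibition), compound 3 stands second highest of the three numbers. Its nearest neighbour is compound 2, with a 1.3-fold higher number from compound 2 to compound 3 (0.11 log units; within the scatter), a gap within the scatter. The furthest is compound 1, with a 3.5-fold lower number from compound 1 to compound 3 (0.55 log units; beyond the scatter), and the parallel step a 4.5-fold lower number from compound 1 to compound 2 (0.66 log units; beyond the scatter) shows the same size once nitro is exchanged for methoxy. The two steps beyond the scatter both start from compound 1; between compound 2 and compound 3 nothing beyond the scatter appears.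

Compound 4 `Cc1cc(Nc2ccc(C(=O)/C=C/c3ccc4ccccc4c3)cc2)n2nc(SCc3ccccc3)nc2n1` is not yet measured. It differs from compound 3 in one place: hydrogen in place of fluoro on an aromatic carbon. Within the data shown here, no measured step removes a group from this position outright, so the expectation rests on the small spread between compound 2 and compound 3, both of which carry an uncharged group there. Compound 4 is therefore estimated to show a step of a 1.1-fold higher number from compound 3 to compound 4 (0.04 log units; within the scatter), within the scatter. The estimate for compound 4 in this assay is 350 nM, with a range from 150 nM to 800 nM.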

Compound 4, half-maximal inhibitory concentration: 300 nM
The estimate for compound 4 lay 1.2-fold (0.07 log units) above the measured number, and the stated range covers the measured number.
By their numbers in this assay, from the lowest: compounds 2, 4 and 3 (each within the scatter of the next); then compound 1.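

In this assay, the bare phenyl ring of compound 4 adds a case with no substituent at this position, and it sits within the scatter of the fluoro compound (a 1.1-fold lower number from compound 3 to compound 4 (0.03 log units; within the scatter)) and of the methoxy compound (a 1.2-fold higher number from compound 2 to compound 4 (0.08 log units; within the scatter)). Hydrogen, fluoro and methoxy therefore cannot be told apart here, so a substituent on this ring is not required to match compound 2 and compound 3, and nitro alone separates from the unsubstituted ring (a 3.8-fold lower number from compound 1 to compound 4 (0.58 log units; beyond the scatter)). No measurement at hand offers a reason for the separate place of the nitro compound.

Open, as far as these compounds go, is whether an amine or a carboxylic acid at this position would stay with hydrogen, fluoro and methoxy or fall with nitro. Also open, from the compounds shown here alone, is whether a longer chain in place of the benzyl link would keep the number within the scatter of compound 4.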